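Moving One Methyl on the Amide-Bound Phenyl Ring

This account rests on a few compounds, and the source may have more. Where it says the series, first, only, none or still open, it means among the compounds named here.

Compound 1 `Cc1ccc(C)c(NC(=O)CSc2nnc(-c3ccoc3C)n2Cc2ccco2)c1`: 398 nM
Compound 2 `Cc1cccc(C)c1NC(=O)CSc1nnc(-c2ccoc2C)n1Cc1ccco1`: > 15800 nM

Compound 1 and compound 2 share the same core and differ only in the dimethylphenyl group on the amide nitrogen. In a functional assay on CHO cells for antagonist activity at Orexin receptor type 2 (Homo sapiens), read by FLIPR and calcium flux (a lower number here means a stronger inhibitor, a higher number a weaker inhibitor), compound 1 gives 398 nM. For compound 2 this assay reports > 15800 nM, which is a limit of the assay and not a number. The step of an at least 39-fold higher number from compound 1 to compound 2 (1.59 log units; beyond the scatter) is large, so compound 2 sits at the limit of > 15800 nM in this assay, at which 1 of the 2 values shown sits, the weak end of what has been measured.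

Compound 3 `Cc1cccc(NC(=O)CSc2nnc(-c3ccoc3C)n2Cc2ccco2)c1C` arises from compound 2 through the change (2,3-dimethylphenyl in place of 2,6-dimethylphenyl on an amide-type nitrogen). Going by the values given here, the one measured step bearing on it, an at least 39-fold higher number from compound 1 to compound 2 (1.59 log units; beyond the scatter), shows that relocating a single methyl can shift the number strongly. Moving a methyl away from the 2,6-dimethylphenyl pattern is therefore expected to lower the number, though how far is uncertain. For compound 3 the estimate is 2500 nM, between 400 nM and 15800 nM, an expected step of an at least 6.3-fold lower number from compound 2 to compound 3 (0.80 log units; beyond the scatter).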

Compound 3, inhibition constant: > 15800 nM
Compound 3 ended at the assay's limit; the forecaster's own chance of this, stated with the estimate: 30%; middle value at least 6.3-fold (0.80 log units) from the limit.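

Replacing the 2,5-dimethylphenyl on the amide nitrogen with 2,3-dimethylphenyl gives an at least 39-fold higher number from compound 1 to compound 3 (1.59 log units; beyond the scatter), so the large loss is not confined to the 2,6-dimethylphenyl group. The value of compound 3 is a limit of the assay, as is that of compound 2, and the step between these two cannot be read. Among the three dimethylphenyl groups shown, only the 2,5-dimethylphenyl of compound 1 gives a readable number, and the other two share the same ceiling: the limit of > 15800 nM in this assay, at which 2 of the 3 values shown sit.

Which of the two methyls in compound 1 matters more remains open, as does whether either one is needed at all. A plain phenyl group, or a chlorine or methoxy group in place of one methyl, could help answer this.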